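The compounds below may be only part of what the source reports. "The series", "measured", "known", "first", "only" and "open" are said of these compounds alone.

Compound 1 `COc1cc(C(=O)/C=C/c2ccc(OCCCC(=O)NCCCNCCCCN)cc2)cc(OC)c1OC` gives > 100000 nM in a functional assay on HT-29 cells (Homo sapiens) for antiproliferative activity, read by MTT assay, with a stated time of 48 h (a higher number here means a weaker inhibitor, a lower number a stronger inhibitor), and this value is a limit of the assay, not a number. Going by the values given here, compound 2 `COc1ccc(/C=C/C(=O)c2cc(OC)c(OC)c(OC)c2)cc1OCCCC(=O)NCCCCN(CCCN)CCCCN` gives 74700 nM in this assay, the only actual number so far. Compound 3 `COc1ccc(/C=C/C(=O)c2cc(OC)c(OC)c(OC)c2)cc1OCCCC(=O)NCCCCNCCCN` differs from compound 2 at one place on the chain: hydrogen in place of 4-aminobutyl on an amine nitrogen. Among the compounds with values here, no measured pair shows this change, so the expectation is loose. Within the data shown here, compound 1 also has hydrogen on an amine nitrogen of its chain, and its limit of > 100000 nM is the only guide to the expected direction. The expected change is small, within the usual scatter and leaning towards weaker inhibition, with an estimated 1.2-fold higher number from compound 2 to compound 3 (0.08 log units; within the scatter). For compound 3 the estimate is 90000 nM, with an expected range of 45000 nM to 180000 nM.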

Compound 3, half-maximal inhibitory concentration: > 100000 nM
Compound 3: a limit, no number; the forecaster's own chance of this, stated with the estimate: 45%; middle value at least 1.1-fold (0.04 log units) from the limit.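

Going by these compounds alone, this is the first step that can be read at a single place: on an amine nitrogen whose other neighbours are saturated chain carbons, hydrogen in place of 4-aminobutyl gives an at least 1.3-fold higher number from compound 2 to compound 3 (0.12 log units; that floor lies within the scatter) in this assay. Compound 3 gives > 100000 nM, which is a limit and not a number. The step is therefore only a floor, and its true size cannot be read because the reading for this change stops at the limit: the limit of > 100000 nM in this assay, at which 2 of the 3 values shown sit.

On these data alone, it remains open whether the 4-aminobutyl group contributes anything beyond the scatter at this nitrogen. Also open, as far as these compounds go, is whether a methyl group, a longer aminoalkyl chain or an amide on the same nitrogen would give a number clearly different from that of compound 2.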